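The source may hold more compounds than are shown below. What is called first, only, known or untested is meant among the compounds shown, and "the series" means these compounds.

Compound 1 `CCOC(=O)Cn1ncc2cncn2c1=O` in a functional assay for inhibition, with Homo sapiens as the target (on this read-out lower numbers stand for stronger inhibition and higher numbers for weaker inhibition), gives > 48000 nM, a limit of the assay rather than a number.
Compound 2 `C=CCn1ncc2cnc(Cc3ccccc3)n2c1=O` in this assay gives > 48000 nM, again only a limit.
Compound 3 `C=CCn1ncc2cnc(COC)n2c1=O` in this assay gives > 48000 nM, likewise a limit.

Compound 3 therefore stands without a number of its own; the step that the two limits leave unreadable from compound 2 to compound 3 cannot be read, since both ends are limits, and the same holds across the whole set because of the limit of > 48000 nM in this assay, at which 3 of the 3 values shown sit. The change from compound 3 to compound 4 `CCOC(=O)Cn1ncc2cnc(COC)n2c1=O` is ethoxycarbonyl in place of vinyl on a saturated chain carbon bound to an aromatic nitrogen. Among the compounds with values here, no measured step isolates this exchange. Compound 1 already carries the entering (ethoxycarbonyl)methyl group but differs from compound 4 in a further place, and it shows only a limit. Within the data shown here, with every value so far sitting at the limit, no direction can be claimed; the step that the limit leaves unreadable from compound 3 to compound 4 is expected to be none that the assay can show. Compound 4 is expected to give 60000 nM, with a range from 20000 nM to 200000 nM, most likely reported again as a limit.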

Compound 4, half-maximal inhibitory concentration: > 48000 nM
Compound 4: only a limit was reported (the forecaster's own chance of this, stated with the estimate: 85%); the middle value lies beyond the limit too.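

Neither the change from compound 3 to compound 4 nor that from compound 1 to compound 4 gives a readable step, since both ends of each are limits: the limit of > 48000 nM in this assay, at which 4 of the 4 values shown sit.

The compounds shown leave open whether any group on the shared core changes the read-out in this assay at all.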